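The compounds below may be only part of what the source reports. "The series", "measured", "known", "first", "only" and "open" are said of these compounds alone.

Compound 1, `O=C(Nc1ccc(Cl)c(-c2nnc3c(Cl)cccn23)c1)c1ccc(Cl)cc1`, gives > 100000 nM in a functional assay on HeLa cells (Homo sapiens) for antiproliferative activity, read by MTT assay, with a stated time of 72 h (a higher number here means a weaker inhibitor, a lower number a stronger inhibitor), a limit of the assay and not a number.
Compound 2, `O=C(Nc1ccc(Cl)c(-c2nnc3c(Cl)cccn23)c1)c1cccc(Cl)c1`, gives > 100000 nM in this assay, likewise only a limit.
Compound 3, `Cc1cc(Cl)ccc1C(=O)Nc1ccc(Cl)c(-c2nnc3c(Cl)cccn23)c1`, gives > 100000 nM in this assay, also only a limit.

Compound 3 thus stands at the limit that every measured compound shares, as recorded in the limit of > 100000 nM in this assay, at which 3 of the 3 values shown sit. The change to compound 4, `CS(=O)(=O)c1cccc(C(=O)Nc2ccc(Cl)c(-c3nnc4c(Cl)cccn34)c2)c1`, is 3-(methylsulfonyl)phenyl in place of 4-chloro-2-methylphenyl on a carbonyl carbon. For the measured compounds named here, the steps that bear on it are a step that the two limits leave unreadable from compound 1 to compound 3 and a step that the two limits leave unreadable from compound 2 to compound 3, together with a step that the two limits leave unreadable from compound 1 to compound 2; all three remain unreadable, so neither a size nor a direction can be taken from them. The expected step from compound 3 is a number no higher from compound 3 to compound 4 (the limit leaves the size open), with the result likely to be a limit once more. Compound 4 is therefore estimated at 100000 nM, within a range from 20000 nM to 300000 nM.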

Compound 4, half-maximal inhibitory concentration: 86400 nM
For compound 4 the middle estimate is 1.2-fold (0.06 log units) above the measured one, and the stated range covers the measured number.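

On the carbonyl carbon, 3-(methylsulfonyl)phenyl is the only group shown that gives a number and not a limit in this assay, while the other three groups share one limit: the limit of > 100000 nM in this assay, at which 3 of the 4 values shown sit.
The change reads as an at least 1.1-fold lower number from compound 3 to compound 4 (0.06 log units; that floor lies within the scatter), as an at least 1.1-fold lower number from compound 2 to compound 4 (0.06 log units; that floor lies within the scatter), with methylsulfonyl in place of chloro, and as an at least 1.1-fold lower number from compound 1 to compound 4 (0.06 log units; that floor lies within the scatter). Each of these is only a floor, and the steps among compound 1, compound 2 and compound 3 cannot be read.

From the compounds shown here alone, the true size of the change stays open. So does whether an amine or a carboxylic acid in place of methylsulfonyl would also give a number in this assay.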